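The source may hold more compounds than are shown below. What is called first, only, known or untested is meant among the compounds shown, and "the series" means these compounds.

Working notes on the series. The shared core is carried by compound 1 `COc1ncc(NC(=O)[C@H](C)[C@H]2CC[C@@H](c3ccnc4ccc(F)cc43)CC2)cn1`, compound 2 `C[C@H](NC(=O)[C@H](C)[C@H]1CC[C@@H](c2ccnc3ccc(F)cc32)CC1)c1ccc(Cl)cc1` and compound 3 `C[C@@H](NS(=O)(=O)c1ccc(Cl)cc1)[C@H]1CC[C@@H](c2ccnc3ccc(F)cc32)CC1`. Within the data shown here, in an assay on tissue (M109 cells) for inhibition of Indoleamine 2,3-dioxygenase 1 (Mus musculus), with stated times of 2 h and 18 h (on this read-out lower numbers stand for stronger inhibition and higher numbers for weaker inhibition), compound 1 gives 92 nM and compound 2 gives 870 nM; the only sized step is a 9.5-fold higher number from compound 1 to compound 2 (0.98 log units; beyond the scatter). For compound 3 this assay returns only a limit, > 1000 nM, so compound 3 sits at the limit of > 1000 nM in this assay, at which 1 of the 3 values shown sits, and its true number is not known. Compound 4 `C[C@@H](NC(=O)C1CCCCC1)[C@H]1CC[C@@H](c2ccnc3ccc(F)cc32)CC1` is the next entry: cyclohexylcarbonyl in place of (4-chlorophenyl)sulfonyl on an amine nitrogen. Among the measured compounds shown here, no measured step touches this change, so nothing sizes it. Compound 4 is therefore expected near 1500 nM, within 400 nM to 6000 nM, which means an expected step that the limit leaves unreadable from compound 3 to compound 4 from the limit of compound 3.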

Compound 4, half-maximal inhibitory concentration: 86 nM
For compound 4 the middle estimate is 17-fold (1.24 log units) above the measured one; the whole stated range lies above it.
By their numbers in this assay, from the lowest: compounds 4 and 1 (each within the scatter of the next); then compound 2. At a limit, above all of these: compound 3.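

On the amine nitrogen, cyclohexylcarbonyl in place of (4-chlorophenyl)sulfonyl gives an at least 11-fold lower number from compound 3 to compound 4 (1.06 log units; beyond the scatter) in this assay, so this position can carry a number well clear of the limit held by compound 3. The step is a bound and not a measured size, since one of its ends is a limit: the limit of > 1000 nM in this assay, at which 1 of the 4 values shown sits.

The change replaces the sulfonyl with a carbonyl and the aromatic ring with a non-aromatic ring at once, and the compounds shown do not separate the two. A benzoyl or a cyclohexylsulfonyl group on the same nitrogen would tell them apart.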